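This account rests on a few compounds, and the source may have more. Where it says the series, first, only, none or still open, it means among the compounds named here.

Compound 2 `COc1cc(-c2cc(/C=C/C(=O)c3ccc(Cl)c(Cl)c3)[nH]n2)cc(OC)c1OC` stands at the weaker end of the two compounds measured in a functional assay on MDA-MB-231 cells (Homo sapiens) for cytotoxicity, read by sulforhodamine B assay, with a stated time of 48 h, tested at 10 uM; a lower number here means a stronger effect, a higher number a weaker effect of the compound at the concentration tested: compound 2 gives 47%, whereas compound 1 `COc1cc(-c2cc(/C=C/C(=O)c3ccc(N)cc3)[nH]n2)cc(OC)c1OC` gives 7%, and the step of a number 40 percentage points higher from compound 1 to compound 2 (beyond the scatter) is beyond the scatter. Compound 3 `COc1ccc(C(=O)/C=C/c2cc(-c3cc(OC)c(OC)c(OC)c3)n[nH]2)cc1OC` differs from compound 2 in one place: 3,4-dimethoxyphenyl in place of 3,4-dichlorophenyl on a carbonyl carbon. For the measured compounds named here, the only measured step, a number 40 percentage points higher from compound 1 to compound 2 (beyond the scatter), changed the same ring to a different group, so it offers no direct guide. Compound 3 is therefore expected to move a little toward stronger effect, a step of a number 17 percentage points lower from compound 2 to compound 3 (beyond the scatter). The estimate for compound 3 is 30%, with a range from 8% to 60%.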

Compound 3, a percentage reported as activity, at one concentration (the size of the read-out at that concentration, not a potency): -82%
For compound 3 the middle estimate is 112 percentage points above the measured one, outside the stated range (below it).
By their numbers in this assay, from the lowest: compound 3; then compound 1; then compound 2.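

For the compounds shown here, changing the ring on the carbonyl carbon does more than the first pair of compounds showed: 3,4-dimethoxyphenyl gives the step of a number 129 percentage points lower from compound 2 to compound 3 (beyond the scatter), and the step of a number 89 percentage points lower from compound 1 to compound 3 (beyond the scatter). Compound 3 is therefore the strongest of the three, surpassing even compound 1, so this position can still gain a great deal beyond the 4-aminophenyl ring. No measurement shown here explains this gain. As far as these compounds go, it also remains open whether a phenyl ring carrying a single methoxy group, or hydroxyl groups instead, would keep this strong effect.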